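A few compounds are considered here, and "the series" means these few. Any claim that something is new, unique, unknown or untested is made for them only; others in the source may bear on it.

Measured so far in a functional assay on PC-3 cells (Homo sapiens) for cytotoxicity, read by MTT assay, with a stated time of 72 h; a higher number here means that more compound is tolerated, a lower number that less compound is tolerated:

- compound 1, `CS/C(=N\C(=O)c1sccc1Cl)NC(=O)c1sccc1Cl`: 90100 nM
- compound 2, `CS/C(=N\C(=O)c1csc([N+](=O)[O-])c1)NC(=O)c1csc([N+](=O)[O-])c1`: > 100000 nM
- compound 3, `CS/C(=N\C(=O)c1cc2ccccc2s1)NC(=O)c1cc2ccccc2s1`: 72600 nM

In this assay compound 2 gives only a limit, > 100000 nM, and no number; (the limit of > 100000 nM in this assay, at which 1 of the 3 values shown sits). Of the two actual numbers, compound 1 with 90100 nM and compound 3 with 72600 nM lie within the scatter of each other, so no order between them can be read from this assay. All three carry the same shared core of compound 1, differing only in the aryl carbonyl groups at both ends.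

Compound 4, `C[Se]/C(=N\C(=O)c1sccc1Cl)NC(=O)c1sccc1Cl`, is not yet measured. It differs from compound 1 in one place: a group of 2 heavy atoms (1 carbon, 1 selenium; no ring) in place of a group of 2 heavy atoms (1 carbon, 1 sulfur; no ring), on a carbon with a double bond to nitrogen. Among the measured compounds shown here, no measured pair isolates a change of this kind, so no measured step can be pointed to for its size. The expectation is a step from compound 1 to compound 4 of a 1.2-fold lower number from compound 1 to compound 4 (0.08 log units; within the scatter), that is none beyond the scatter. Compound 4 is therefore estimated at 75000 nM, with a range from 30000 nM to 160000 nM, with some chance that this assay again reports only a limit.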

Compound 4, concentration lethal to 50% of the cells: > 100000 nM
Compound 4 gave a limit, no number (the forecaster's own chance of this, stated with the estimate: 25%); middle value at least 1.3-fold (0.12 log units) away from the limit.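

Among the compounds shown here, the exchange of methylsulfanyl for its selenium counterpart, on a carbon with a double bond to nitrogen, is the first change confined to one place, with the aryl carbonyl groups of compound 1 held fixed. In this assay compound 4 gives > 100000 nM as a limit of the assay and not a number. The change reads as an at least 1.1-fold higher number from compound 1 to compound 4 (0.04 log units; that floor lies within the scatter) and shows no drop in the number with selenium on this carbon, while compound 4 joins the compounds at the limit: the limit of > 100000 nM in this assay, at which 2 of the 4 values shown sit.

How far compound 4 truly lies from compound 1 cannot be read while its value stays a limit. Still open, from the compounds shown here alone, are whether an amine or a longer chain such as ethylsulfanyl at this carbon would bring a measurable number, and whether the selenium exchange gives the same result with the aryl carbonyl groups of compound 3.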